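This account rests on a few compounds, and the source may have more. Where it says the series, first, only, none or still open, it means among the compounds named here.

In an ADME assay on microsomes from liver (Mus musculus, strain CD-1) for metabolic stability, read by LC-MS, tested at 2 uM (a higher number here means that the compound lasts longer, a lower number that the compound disappears faster), compound 1 `CN1CCC(NC(=O)c2ccncc2Nc2cc(-c3ccc4ccn(C)c4c3)c3nccnc3c2)CC1=O` gives 0.717 h. Compound 2 `Cn1ccc2ccc(-c3cc(Nc4cnccc4C(=O)NCC4COCCN4)cc4nccnc34)cc21` is reported only as a limit, > 1 h. Compound 3 `CC(=O)N1CC(CNC(=O)c2ccncc2Nc2cc(-c3ccc4ccn(C)c4c3)c3nccnc3c2)C1` is also reported only as a limit, > 1 h, so its position is bounded and not exact. Among the measured compounds shown here, the series so far shows (the limit of > 1 h in this assay, at which 2 of the 3 values shown sit).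

Compound 4 `CN1CCC(N(C)C(=O)c2ccncc2Nc2cc(-c3ccc4ccn(C)c4c3)c3nccnc3c2)C1` differs from compound 3 by methyl(1-methylpyrrolidin-3-yl)amino in place of ((1-acetylazetidin-3-yl)methyl)amino on a carbonyl carbon.

The measured changes at this amide-type nitrogen are an at least 1.3-fold higher number from compound 1 to compound 2 (0.14 log units; that floor lies within the scatter) and an at least 1.3-fold higher number from compound 1 to compound 3 (0.14 log units; that floor lies within the scatter), while a step that the two limits leave unreadable from compound 2 to compound 3. None gives a size beyond the scatter. With compound 1 at 0.717 h as the one numeric anchor, only a small downward move is expected, estimated as an at least 1.2-fold lower number from compound 3 to compound 4 (0.09 log units; that floor lies within the scatter). Compound 4 is expected at 0.8 h, with an estimated range of 0.35 h to 1.6 h.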

Compound 4, half-life: > 1 h
Compound 4: only a limit was reported (the forecaster's own chance of this, stated with the estimate: 35%); middle value at least 1.2-fold (0.09 log units) away from the limit.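

In this assay compound 4, the only compound shown with methyl(1-methylpyrrolidin-3-yl)amino on this carbonyl carbon and so without the amide hydrogen, is reported as > 1 h which is a limit only. This change gives an at least 1.3-fold higher number from compound 1 to compound 4 (0.14 log units; that floor lies within the scatter) while the steps to compound 2 and compound 3 cannot be read. Loss of the amide hydrogen therefore brings no readable drop, and the readings crowd at one limit: the limit of > 1 h in this assay, at which 3 of the 4 values shown sit.

From the compounds shown here alone, the exact half-lives of compound 2, compound 3 and compound 4 stay open, so no order among them can be given. Also open, going by these compounds, is how a carboxylic acid or a primary amine on the group at this carbonyl carbon would read.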